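The source may hold more compounds than are shown below. What is called first, only, known or untested is meant among the compounds shown, and "the series" means these compounds.

Measured so far in a functional assay on CHO cells with adenosine receptor A1 (Homo sapiens) as the target, read by cAMP accumulation and immunoassay, with a stated time of 6 min, tested at 0.1 uM; a higher number here means a weaker effect of the compound at the concentration tested, a lower number a stronger effect:
compound 1, `Nc1scc(CN2CCN(c3cccc(Cl)c3Cl)CC2)c1C(=O)c1ccc(Cl)cc1`: 3.2%
compound 2, `Nc1scc(CN2CCN(c3ccc([N+](=O)[O-])cc3)CC2)c1C(=O)c1ccc(Cl)cc1`: -13%
compound 3, `Nc1scc(CN2CCN(c3cccnc3)CC2)c1C(=O)c1ccc(Cl)cc1`: 3.4%

Compound 3 holds the highest of the three numbers, but its nearest neighbour is compound 1, with a number 0.2 percentage points higher from compound 1 to compound 3 (within the scatter), so the two are not separated. Only compound 2 sits apart: a number 16.4 percentage points higher from compound 2 to compound 3 (beyond the scatter).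

The next compound, compound 4, is `Nc1scc(CN2CCN(c3ccc(F)cc3F)CC2)c1C(=O)c1ccc(Cl)cc1`. It differs from compound 3 in one place: 2,4-difluorophenyl in place of pyridin-3-yl on an amine nitrogen in a ring.

Among the measured compounds shown here, the step that bears most directly on this is the one from compound 1 to compound 3, since compound 1 carries 2,3-dichlorophenyl on the same ring nitrogen; that exchange of one six-membered aromatic ring for another gave a number 0.2 percentage points higher from compound 1 to compound 3 (within the scatter). The exchange that did move the number, a number 16.2 percentage points lower from compound 1 to compound 2 (beyond the scatter), involved 4-nitrophenyl, a group absent from compound 4. For the measured compounds named here, with only three measured compounds, no trend across this position can be claimed; compound 2 is the only one standing apart.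

The expectation for compound 4 is therefore a number close to compound 3, with a number 1.4 percentage points lower from compound 3 to compound 4 (within the scatter), inside the usual scatter. Compound 4 is estimated at 2%, in the range -12% to 14%.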

Compound 4, a percentage reported as activity, at one concentration (the size of the read-out at that concentration, not a potency): -17%
The estimate for compound 4 lay 19 percentage points above the measured number, and the stated range ends above it.
By their numbers in this assay, from the lowest: compounds 4 and 2 (each within the scatter of the next); then compounds 1 and 3 (each within the scatter of the next).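

In this assay, among the compounds shown here, 4-nitrophenyl is no longer the only group on the amine nitrogen in a ring that gives a low number: the result is a number 20.4 percentage points lower from compound 3 to compound 4 (beyond the scatter) and, against the dichlorinated ring, a number 20.2 percentage points lower from compound 1 to compound 4 (beyond the scatter) with 2,4-difluorophenyl in place of 2,3-dichlorophenyl. Exchange of 4-nitrophenyl for 2,4-difluorophenyl gives a number 4 percentage points lower from compound 2 to compound 4 (within the scatter) and leaves those two groups unseparated, so the four compounds now form two sets, compounds 2 and 4 at the low end and compounds 1 and 3 at the high end. The split does not follow the count of hetero atoms in the ring or a simple division into carbon-only rings and others, as the carbon-only ring of compound 1 falls in the same set as the pyridin-3-yl of compound 3, and no measurement shown accounts for this split.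

Going by these compounds, whether the low numbers depend on the kind of substituent on the phenyl ring or on where it stands remains open, and a methoxy group, a carboxylic acid or an unsubstituted phenyl at this position would test that. A saturated ring such as cyclohexyl on the same nitrogen is also untested here, and a read-out at one concentration gives no potency for any of these compounds.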